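The source may hold more compounds than are shown below. What is called first, only, known or untested is meant among the compounds shown, and "the series" means these compounds.

Measured so far:
compound 1 `COC1Cc2c(csc2-c2cccc3ccccc23)C2(CCN(Cc3ccccc3)CC2)O1` — in an assay on membranes from brain for displacement of a labelled ligand from Sigma non-opioid intracellular receptor 1 (Cavia porcellus), read by scintillation counting, with a stated time of 120 min (on this read-out lower numbers stand for stronger inhibition and higher numbers for weaker inhibition), compound 1 gives 5 nM
compound 2 `COC1Cc2c(csc2-c2ccc([N+](=O)[O-])cc2)C2(CCN(Cc3ccccc3)CC2)O1` — in this assay compound 2 gives 1 nM

For the measured compounds named here, compound 2 holds the lowest number of the two; the only step, a 5.0-fold lower number from compound 1 to compound 2 (0.70 log units; beyond the scatter), sets it apart from compound 1. Compound 3 `COC1Cc2c(csc2-c2ccc(C(C)=O)cc2)C2(CCN(Cc3ccccc3)CC2)O1` carries acetyl in place of nitro on an aromatic carbon. Going by the values given here, no measured step exchanges one group for another on that ring; the single step concerns a different change and bears on this one only loosely. In this assay compound 3 is therefore expected near compound 2, with a step of a 2.5-fold higher number from compound 2 to compound 3 (0.40 log units; beyond the scatter), most likely within the scatter, estimated at 2.5 nM (range 0.8 nM to 8 nM).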

Compound 3, inhibition constant: 1.6 nM
Compound 3: middle estimate off by 1.6-fold (0.19 log units), on the high side, and the stated range covers the measured number.
By their numbers in this assay, from the lowest: compounds 2 and 3 (each within the scatter of the next); then compound 1.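

In this assay, acetyl in place of nitro at this position, para to a large group, gives a 1.6-fold higher number from compound 2 to compound 3 (0.20 log units; within the scatter), so the low number does not depend on nitro: a second group of 3 heavy atoms holds the same level. Replacing naphthalen-1-yl with 4-acetylphenyl gives a 3.1-fold lower number from compound 1 to compound 3 (0.49 log units; beyond the scatter), so a lower number on leaving naphthalen-1-yl now appears with two different 4-substituted phenyl groups. Nothing available explains either step. On these data alone, whether an amine, a carboxylic acid or a plain hydrogen at this place stays at this level remains open.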